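Swapping Bromo for Methyl on the Acrylamide-Type Chain

The compounds below may be only part of what the source reports. "The series", "measured", "known", "first", "only" and "open" are said of these compounds alone.

Measured in a functional assay on NCI-H1975 cells (Homo sapiens) for antiproliferative activity, read by sulforhodamine B assay, with a stated time of 72 h; a higher number here means a weaker inhibitor, a lower number a stronger inhibitor:
compound 1 `C/C=C/C(=O)Nc1cc(Nc2nccc(-c3cn(C)c4ccccc34)n2)c(OC)cc1N(C)CCN(C)C`: 496 nM
compound 2 `C=C(Cl)C(=O)Nc1cc(Nc2nccc(-c3cn(C)c4ccccc34)n2)c(OC)cc1N(C)CCN(C)C`: 241 nM
compound 3 `C=C(Br)C(=O)Nc1cc(Nc2nccc(-c3cn(C)c4ccccc34)n2)c(OC)cc1N(C)CCN(C)C`: 147 nM

Compound 3, at 147 nM, shares the low end of this small set with compound 2, the two lying within the scatter of each other. Compound 4 `C=C(C)C(=O)Nc1cc(Nc2nccc(-c3cn(C)c4ccccc34)n2)c(OC)cc1N(C)CCN(C)C` carries methyl in place of bromo on a double-bonded chain carbon bound to a carbonyl carbon. Among the measured compounds shown here, no measured step makes this exact exchange. The nearest are a 3.4-fold lower number from compound 1 to compound 3 (0.53 log units; beyond the scatter) and a 2.1-fold lower number from compound 1 to compound 2 (0.31 log units; beyond the scatter), both modest, while a 1.6-fold lower number from compound 2 to compound 3 (0.21 log units; within the scatter) stays within the scatter. Compound 1, which also lacks a halogen there, gives 496 nM, so a modest rise in the number is expected in this assay. The expected change is a 2.6-fold higher number from compound 3 to compound 4 (0.41 log units; beyond the scatter). For compound 4 the estimated value is 380 nM, with an expected range of 140 nM to 1000 nM.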

Compound 4, half-maximal inhibitory concentration: 486 nM
For compound 4 the middle estimate is 1.3-fold (0.11 log units) below the measured one; the measured number falls inside the stated range.
By their numbers in this assay, from the lowest: compounds 3, 2, 4 and 1 (each within the scatter of the next, the first and the last beyond it).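

In this assay, the exchange of bromo for methyl on a double-bonded chain carbon bound to a carbonyl carbon gives a 3.3-fold higher number from compound 3 to compound 4 (0.52 log units; beyond the scatter), so methyl does not hold the level of bromo at this place. Methyl in place of chloro gives a 2.0-fold higher number from compound 2 to compound 4 (0.30 log units; within the scatter), and 1-methylethenyl in place of prop-1-en-1-yl gives a 1.0-fold lower number from compound 1 to compound 4 (0.01 log units; within the scatter), so only the bromo compound stands apart from compound 4. Nothing measured here gives a reason for these differences.

The compounds shown leave open how fluoro, a nitrile or a dimethylaminomethyl group would fare at this place, and whether an unsubstituted ethenyl would read differently from compound 4.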